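Swapping an Aminophenyl for a Methoxyphenyl on Cytotoxicity

The source may report more compounds than this note shows. Statements on the series, on what has been measured and on what is new or still open speak of the compounds shown alone.

Compound 1 `COc1ccc(-c2cc3cc(C)ccc3c(-c3cccc(O)c3)n2)cc1OC`: 13500 nM
Compound 2 `COc1ccc(-c2cc3cc(C)ccc3c(-c3cccc(N)c3)n2)cc1OC`: 5600 nM

In an ADME assay on MCF-10A cells (Homo sapiens) for cytotoxicity, read by CCK-8 assay and cell counting, with a stated time of 72 h (a lower number here means a stronger inhibitor, a higher number a weaker inhibitor), compound 2 gives 5600 nM, the lowest of the two numbers; its nearest neighbour is compound 1, where a 2.4-fold lower number from compound 1 to compound 2 (0.38 log units; beyond the scatter). Compound 3 `COc1ccc(-c2nc(-c3ccc(OC)c(OC)c3)cc3cc(C)ccc23)cc1` is not yet measured. It differs from compound 2 in one place: 4-methoxyphenyl in place of 3-aminophenyl on an aromatic carbon. Among the compounds with values here, no measured step makes exactly this exchange; the only step known, a 2.4-fold lower number from compound 1 to compound 2 (0.38 log units; beyond the scatter), traded hydroxy for amino and was modest. The loss of the amino group suggests a modest move back toward higher numbers, with wide uncertainty. Compound 3 is expected to give 10000 nM, within 3500 nM to 30000 nM, which would mean a 1.8-fold higher number from compound 2 to compound 3 (0.25 log units; within the scatter).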

Compound 3, half-maximal inhibitory concentration: > 50000 nM
Compound 3 ended at the assay's limit; the forecaster's own chance of this, stated with the estimate: 10%; at least 5.0-fold (0.69 log units) between middle value and limit.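

At this place, next to the ring nitrogen, the choice of group counts for more than the hydroxy-to-amino exchange suggested: replacing 3-aminophenyl with 4-methoxyphenyl gives an at least 8.9-fold higher number from compound 2 to compound 3 (0.95 log units; beyond the scatter), and replacing 3-hydroxyphenyl with it gives an at least 3.7-fold higher number from compound 1 to compound 3 (0.56 log units; beyond the scatter). Both 3-aminophenyl and 3-hydroxyphenyl give measurable values in this assay, whereas 4-methoxyphenyl does not. Compound 3 gives a limit of the assay and not a number, so the full size of both steps stays unknown: the limit of > 50000 nM in this assay, at which 1 of the 3 values shown sits.

These compounds cannot separate the effect of the group from that of its place on the phenyl ring. As far as these compounds go, what 3-methoxyphenyl or 4-aminophenyl would give remains open.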